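Replacing a piperidinylmethyl group with methoxy on a urea-linked aryl

The compounds below may be only part of what the source reports. "The series", "measured", "known", "first", "only" and "open" are said of these compounds alone.

Compound 1 `CN1CCN(Cc2ccc(NC(=O)Nc3ccc4ncnc(Nc5ccc(F)c(Cl)c5)c4c3)cc2)CC1`: 4000 nM
Compound 2 `C#Cc1cccc(Nc2ncnc3ccc(NC(=O)Nc4ccc(CN5CCN(C)CC5)cc4)cc23)c1`: 2810 nM
Compound 3 `O=C(Nc1ccc(CN2CCCCC2)cc1)Nc1ccc2ncnc(Nc3cccc(C(F)(F)F)c3)c2c1`: 1550 nM

Of the compounds shown here, three sharing a urea-linked core have been measured in a functional assay on A-431 cells (Homo sapiens) for antiproliferative activity, read by MTT assay, with a stated time of 72 h; on this read-out higher numbers stand for weaker inhibition and lower numbers for stronger inhibition. Compound 1 gives 4000 nM and compound 2 gives 2810 nM, the step of a 1.4-fold lower number from compound 1 to compound 2 (0.15 log units; within the scatter) coming from a change at the aniline end. Compound 3 gives 1550 nM, the lowest of the three numbers; its gap to compound 2 lies within the scatter, while its gap to compound 1 lies beyond it.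

Compound 4 `COc1ccc(NC(=O)Nc2ccc3ncnc(Nc4cccc(C(F)(F)F)c4)c3c2)cc1` differs from compound 3 by methoxy in place of (piperidin-1-yl)methyl on an aromatic carbon. Among the measured compounds shown here, none of the measured steps touches this position: the only step recorded, from compound 1 to compound 2, concerns the other end of the molecule and lies within the scatter. There is therefore no basis for expecting a step beyond the scatter in this assay, in either direction. Compound 4 is estimated to fall near compound 3, at about 1800 nM, with a range from 500 nM to 6000 nM, which means an expected step of a 1.2-fold higher number from compound 3 to compound 4 (0.06 log units; within the scatter).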

Compound 4, half-maximal inhibitory concentration: 4950 nM
The estimate for compound 4 lay 2.8-fold (0.44 log units) below the measured number; low and high end bracket the measured number.
By their numbers in this assay, from the lowest: compounds 3, 2, 1 and 4 (each within the scatter of the next, the first and the last beyond it).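

In this assay the change on this aromatic carbon gives a 3.2-fold higher number from compound 3 to compound 4 (0.50 log units; beyond the scatter) and is the only step shown at this position, so the position does respond to substitution: methoxy in place of (piperidin-1-yl)methyl goes with weaker inhibition. The change removes a six-membered non-aromatic ring and its nitrogen together, and this single step cannot separate the loss of that ring from the arrival of the methoxy oxygen. Nothing measured here accounts for the size of the step.

The compounds shown leave open what a dimethylaminomethyl group, a morpholin-4-ylmethyl group or a plain methyl group would give on this carbon. They also leave open whether the same change would give a similar step with 3-chloro-4-fluorophenyl or 3-ethynylphenyl at the other end of the molecule.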